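Swapping the piperazine linker on a quinoline antiproliferative scaffold

A few compounds are considered here, and "the series" means these few. Any claim that something is new, unique, unknown or untested is made for them only; others in the source may bear on it.

Of the compounds shown here, two have been measured in a functional assay on SK-BR-3 cells (Homo sapiens) for antiproliferative activity, read by MTT assay, with a stated time of 72 h; a lower number here means a stronger inhibitor, a higher number a weaker inhibitor. Compound 1 `Cc1cc(NCCN2CCN(C)CC2)nc2ccc(NC(=O)c3ccc(Cl)c(Cl)c3)cc12` gives 2690 nM, the lowest number of the two. Compound 2 `CCN1CCN(c2cc(C)c3cc(NC(=O)c4cccc(Br)c4)ccc3n2)CC1`, which carries a different benzamide as well as a different piperazine group, gives 13300 nM, a gap from compound 1 that lies beyond the usual scatter.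

Compound 3 `CCN1CCN(c2cc(C)c3cc(NC(=O)c4ccc(Cl)c(Cl)c4)ccc3n2)CC1` is not yet measured. It differs from compound 1 in one place: 4-ethylpiperazin-1-yl in place of (2-(4-methylpiperazin-1-yl)ethyl)amino on an aromatic carbon. Going by the values given here, no measured pair isolates this change, so its effect is unknown. Because compound 2, which also carries the 4-ethylpiperazin-1-yl group, gives 13300 nM, a move toward weaker inhibition seems more likely than a gain. For compound 3 a step of a 2.2-fold higher number from compound 1 to compound 3 (0.35 log units; beyond the scatter) is expected in this assay, a moderate loss, with wide uncertainty. The estimate for compound 3 is 6000 nM, with a range from 2000 nM to 20000 nM.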

Compound 3, half-maximal inhibitory concentration in the SK-BR-3 assay: 2160 nM
Estimate against measurement, compound 3: 2.8-fold (0.44 log units) above; low and high end bracket the measured number.
By their numbers in the SK-BR-3 assay, from the lowest: compounds 3 and 1 (each within the scatter of the next); then compound 2.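

In the SK-BR-3 assay the swap gives a 1.2-fold lower number from compound 1 to compound 3 (0.10 log units; within the scatter) and so leaves no readable difference between 4-ethylpiperazin-1-yl and (2-(4-methylpiperazin-1-yl)ethyl)amino on this aromatic carbon. In the SK-BR-3 assay the other place does count, as 3,4-dichlorophenyl in place of 3-bromophenyl on the carbonyl carbon gives a 6.2-fold lower number from compound 2 to compound 3 (0.79 log units; beyond the scatter) and so compound 3 matches compound 1 despite the piperazine group it shares with compound 2. In a physicochemical assay for solubility (a higher number here means a more soluble compound, a lower number a less soluble compound), compound 1 gives 106 ug/mL and compound 3 gives 11.3 ug/mL and so the swap costs solubility without a readable shift in the antiproliferative number: the measured solubility of compound 1, 106 ug/mL, and of compound 3, 11.3 ug/mL, a 9.4-fold lower number (0.97 log units; beyond the scatter)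

The compounds shown leave open whether a simple dimethylamino group or a longer chain on this carbon would hold the number in the SK-BR-3 assay and also match compound 1 in the physicochemical assay without loss. From the compounds shown here alone, whether the swap behaves the same with 3-bromophenyl on the carbonyl carbon also stays open.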